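Ring expansion on the amine carried by the shared core

The compounds below may be only part of what the source reports. "The series", "measured", "known", "first", "only" and "open" are said of these compounds alone.

Measured so far:
Compound 1 `Cc1nc(C(NC(=O)C(=O)Nc2ccc(F)cc2F)C2CCCCN2)sc1CCO`: > 105000 nM (a limit of the assay, not a number)
Compound 2 `Cc1nc(C(NC(=O)C(=O)Nc2ccc(Cl)cc2)C2CCCN2)sc1CO`: 45000 nM
Compound 3 `Cc1nc(C(NC(=O)C(=O)Nc2ccc(Cl)cc2)C2CCCN2)sc1CCO`: 42000 nM

In an ADME assay on MT2 cells (Homo sapiens) for cytotoxicity, read by XTT assay, with a stated time of 4 days (a lower number here means that less compound is tolerated, a higher number that more compound is tolerated), compound 2 gives 45000 nM and compound 3 gives 42000 nM; a 1.1-fold lower number from compound 2 to compound 3 (0.03 log units; within the scatter), so the two cannot be told apart. Compound 1 stops at > 105000 nM, which is only a limit. The one further point known here, (the limit of > 105000 nM in this assay, at which 1 of the 3 values shown sits), concerns that limit alone.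

Compound 4 `Cc1nc(C(NC(=O)C(=O)Nc2ccc(Cl)cc2)C2CCCNC2)sc1CO` differs from compound 2 by piperidin-3-yl in place of pyrrolidin-2-yl on a saturated chain carbon bound to an amide-type nitrogen and an aromatic carbon. Among the measured compounds shown here, no measured step touches this part of the molecule; the single step seen, from compound 2 to compound 3, lies elsewhere and within the scatter. The expectation is therefore no step beyond the scatter: no change at the digits printed from compound 2 to compound 4 (within the scatter). Compound 4 is estimated at 45000 nM, with a range from 15000 nM to 135000 nM.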

Compound 4, half-maximal cytotoxic concentration: > 81000 nM
Compound 4: a limit, no number; the forecaster's own chance of this, stated with the estimate: 25%; middle value at least 1.8-fold (0.25 log units) from the limit.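

In this assay, replacing pyrrolidin-2-yl with piperidin-3-yl at this place gives an at least 1.8-fold higher number from compound 2 to compound 4 (0.25 log units; that floor lies within the scatter). As far as these compounds go, compound 4 stops at > 81000 nM, which is a limit of the assay and not a number, so the real size of the step stays unknown. Among the compounds shown here, this is the first readable step at this place, and it shows that this ring change does not bring a lower number.

The compounds shown cannot separate the larger ring from the change of attachment from 2-yl to 3-yl; pyrrolidin-3-yl at this place would address that. From the compounds shown here alone, whether an open-chain amine there would behave alike also remains open.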